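Hydrazone aryl swap on a chloropyrimidine acrylamide series

The source may hold more compounds than are shown below. What is called first, only, known or untested is meant among the compounds shown, and "the series" means these compounds.

Compound 1 `CN(C)C/C=C/C(=O)Nc1cccc(Nc2nc(N/N=C/c3ccc(F)cc3F)ncc2Cl)c1`: 2920 nM
Compound 2 `COc1ccc(/C(C)=N/Nc2ncc(Cl)c(Nc3cccc(NC(=O)/C=C/CN(C)C)c3)n2)cc1`: 6830 nM

In an ADME assay on HT-29 cells (Homo sapiens) for inhibition, read by MTT assay, with a stated time of 72 h (on this read-out higher numbers stand for weaker inhibition and lower numbers for stronger inhibition), compound 2 gives the highest number of the two measured, with compound 1 the nearest at a step of a 2.3-fold higher number from compound 1 to compound 2 (0.37 log units; beyond the scatter). Compound 3 `C/C(=N\Nc1ncc(Cl)c(Nc2cccc(NC(=O)/C=C/CN(C)C)c2)n1)c1ccccn1` differs from compound 2 by pyridin-2-yl in place of 4-methoxyphenyl on a carbon with a double bond to nitrogen. For the measured compounds named here, only the step from compound 1 to compound 2 touches this region, and it was modest; it swapped a different aryl and does not bear directly on the pyridin-2-yl change. A step of no more than the scatter is therefore expected, a 1.4-fold lower number from compound 2 to compound 3 (0.14 log units; within the scatter). Compound 3 is estimated at 5000 nM, between 1500 nM and 16000 nM.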

Compound 3, half-maximal inhibitory concentration: 120 nM
Beside the measured number, compound 3's estimate is 42-fold (1.62 log units) above it, outside the stated range (below it).
By their numbers in this assay, from the lowest: compound 3; then compound 1; then compound 2.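

In this assay, the place on a carbon with a double bond to nitrogen proves far more sensitive than the earlier step suggested: pyridin-2-yl in place of 4-methoxyphenyl gives a 57-fold lower number from compound 2 to compound 3 (1.76 log units; beyond the scatter). The wider group change on a nitrogen on an aromatic ring likewise gives a 24-fold lower number from compound 1 to compound 3 (1.39 log units; beyond the scatter). Nothing available explains this gain. Going by these compounds, whether it depends on the ring nitrogen or on the loss of the methoxy group stays open. Phenyl and pyridin-3-yl on this carbon would separate those two readings.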